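The compounds below may be only part of what the source reports. "The series", "measured", "known", "first", "only" and "open" are said of these compounds alone.

Compound 1 `COc1ccc(-c2nn(-c3ccccc3)cc2/C=C/C(=O)c2ccc(OCc3ccccc3)c3c2OC(C)(C)C3)cc1` gives 7900 nM in a functional assay on PC-3 cells (Homo sapiens) for antiproliferative activity, read by MTT assay, with a stated time of 48 h; a lower number here means a stronger inhibitor, a higher number a weaker inhibitor.
Compound 2 `Cc1ccc(-c2nn(-c3ccccc3)cc2/C=C/C(=O)c2ccc(OCc3ccccc3)c3c2OC(C)(C)C3)cc1` gives > 100000 nM in this assay, which is a limit of the assay and not a number.

Compound 2 thus sits at the limit (the limit of > 100000 nM in this assay, at which 1 of the 2 values shown sits), the weaker of the two measured compounds, as an at least 12-fold higher number from compound 1 to compound 2 (1.10 log units; beyond the scatter) shows. Compound 3 `CC1(C)Cc2c(OCc3ccccc3)ccc(C(=O)/C=C/c3cn(-c4ccccc4)nc3-c3cccc([N+](=O)[O-])c3)c2O1` differs from compound 2 by 3-nitrophenyl in place of 4-methylphenyl on an aromatic carbon. Among the measured compounds shown here, no measured step carries this change; the only step seen in this assay exchanges methoxy for methyl at the same place and says nothing about a nitro group. Compound 3 is therefore expected near 40000 nM, within 6000 nM to 100000 nM, with a fair chance of another limit. That expectation amounts to an at least 2.5-fold lower number from compound 2 to compound 3 (0.39 log units; beyond the scatter).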

Compound 3, half-maximal inhibitory concentration: 5900 nM
Compound 3: the middle estimate sits 6.8-fold (0.83 log units) above what was measured, outside the stated range (below it).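

In this assay, the position on the five-membered ring proves able to carry a group other than 4-methoxyphenyl, since 3-nitrophenyl in place of 4-methylphenyl gives an at least 16-fold lower number from compound 2 to compound 3 (1.22 log units; beyond the scatter). Compound 2 stands at a limit of the assay and not a number: the limit of > 100000 nM in this assay, at which 1 of the 3 values shown sits. Replacing 4-methoxyphenyl with 3-nitrophenyl gives a 1.3-fold lower number from compound 1 to compound 3 (0.13 log units; within the scatter), so these two groups cannot be told apart here, and only 4-methylphenyl falls away among the three. On these data alone, whether 4-nitrophenyl or 3-methoxyphenyl would match them remains open, so the effects of the substituent and of its ring position stay unseparated. As far as these compounds go, how an amine or a carboxylic acid on this phenyl ring would read is also open.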